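Cytotoxicity notes: one inverted ring stereocentre

The source may hold more compounds than are shown below. What is called first, only, known or untested is meant among the compounds shown, and "the series" means these compounds.

Measured in a functional assay on J774 cells (Mus musculus) for cytotoxicity, with a stated time of 48 h; a lower number here means a stronger inhibitor, a higher number a weaker inhibitor:
- compound 1 `CC(C)C[C@H](NC(=O)OC(C)(C)C)C(=O)N1CC[C@@H]1C(=O)N1[C@H](C(=O)OCc2ccccc2)[C@H]1C(=O)OCc1ccccc1`: 37200 nM
- compound 2 `CC(C)(C)OC(=O)NCC(=O)N1CCC[C@@H](C(=O)N2[C@H](C(=O)OCc3ccccc3)[C@H]2C(=O)OCc2ccccc2)C1`: > 100000 nM (a limit of the assay)

Among the compounds with values here, compound 1 holds the only numeric value. Compound 2 gives only a limit. Compound 3 `CC(C)C[C@H](NC(=O)OC(C)(C)C)C(=O)N1CC[C@H]1C(=O)N1[C@H](C(=O)OCc2ccccc2)[C@H]1C(=O)OCc1ccccc1` keeps the atoms and bonds of compound 1: the two compounds have the same atoms and bonds and differ only in configuration as drawn: 1 of 4 stereo elements differ; a stereocentre at a saturated ring carbon is drawn R in compound 1 and S in compound 3. Within the data shown here, no measured pair shows what such an inversion does in this assay, so no change beyond the scatter is expected. The expected 1.2-fold higher number from compound 1 to compound 3 (0.08 log units; within the scatter) stays within that scatter. For compound 3 the estimated value is 45000 nM, with an expected range of 18000 nM to 100000 nM.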

Compound 3, half-maximal inhibitory concentration: 37200 nM
Compound 3: the middle estimate sits 1.2-fold (0.08 log units) above what was measured; the range from low to high includes it.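

In this assay, within the data shown here, the inversion of the stereocentre at the saturated ring carbon from R to S gives no change at the digits printed from compound 1 to compound 3 (within the scatter) and so offers the first direct reading of configuration at this position. The earlier compounds shown here held no pair differing in one place. In this pair, on this background, the drawn configuration at this carbon leaves the cytotoxicity reading unmoved.

Going by these compounds, whether that holds at the other stereocentres remains open. On these data alone, it is equally open whether it holds with a free carboxylic acid in place of the benzyl esters.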